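Notes on the step from compound 2 to compound 3

The source may report more compounds than this note shows. Statements on the series, on what has been measured and on what is new or still open speak of the compounds shown alone.

For the measured compounds named here, in a functional assay on SGC-7901 cells (Homo sapiens) for inhibition, read by MTT assay, with a stated time of 24 h (a higher number here means a weaker inhibitor, a lower number a stronger inhibitor), compound 1 `CC1(C)[C@H]2CC[C@]1(C)N(Cc1cn(-c3ccccc3)nn1)C(=O)C2` gives 240 nM and compound 2 `CC1(C)[C@H]2CC[C@]1(C)N(Cc1cn(-c3ccccc3O)nn1)C(=O)C2` gives 410 nM on the numbers so far, the two lying within the scatter of each other. Compound 3 `Cc1cccc(-n2cc(CN3C(=O)C[C@@H]4CC[C@@]3(C)C4(C)C)nn2)c1` differs from compound 2 by 3-methylphenyl in place of 2-hydroxyphenyl on an aromatic nitrogen in one place: 3-methylphenyl in place of 2-hydroxyphenyl on an aromatic nitrogen. Going by the values given here, the one measured step bearing on it is a 1.7-fold higher number from compound 1 to compound 2 (0.23 log units; within the scatter) for hydroxy in place of hydrogen on an aromatic carbon, so no step beyond the scatter is expected in this assay here. The expected step is a 1.4-fold lower number from compound 2 to compound 3 (0.14 log units; within the scatter) on this estimate. Compound 3 is expected at 300 nM within an estimated range of 130 nM to 700 nM in these notes.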

Compound 3, half-maximal inhibitory concentration: 410 nM
Beside the measured number, compound 3's estimate is 1.4-fold (0.14 log units) below it, within the range that was stated.
By their numbers in this assay, from the lowest: compounds 1, 2 and 3 (each within the scatter of the next).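

In this assay the swap of 2-hydroxyphenyl for 3-methylphenyl on the aromatic nitrogen gives no change at the digits printed from compound 2 to compound 3 (within the scatter) and methyl in place of hydrogen on an aromatic carbon gives a 1.7-fold higher number from compound 1 to compound 3 (0.23 log units; within the scatter) in this series. Hydrogen, hydroxy and methyl on this aromatic ring thus leave all three compounds within the scatter of one another, even though 3-methylphenyl carries no hydrogen-bond donor or acceptor. No measurement on hand accounts for these steps. Going by these compounds, whether an amine, a carboxylic acid or a longer chain on this ring would give a step beyond the scatter remains open.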